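A few compounds are considered here, and "the series" means these few. Any claim that something is new, unique, unknown or untested is made for them only; others in the source may bear on it.

Four compounds share one design and differ only in two places. Compound 1 `COC(=O)[C@H](CSCc1ccccc1)NC(=O)c1cc(OC)c(OC)c(OC)c1` and compound 3 `COC(=O)[C@H](CSCc1ccccc1)NC(=O)c1cc(O)c(O)c(O)c1` carry different cores; the difference between these two cores is not broken down here. In an assay on RAW264.7 cells for antagonist activity at Toll-like receptor 2 (Mus musculus), read by Griess assay, with a stated time of 24 h (on this read-out higher numbers stand for weaker inhibition and lower numbers for stronger inhibition), compound 1 gives 32700 nM, and compound 3 gives 60700 nM; the two numbers lie within the usual scatter of each other. Compound 2 `COC(=O)[C@H](CSCc1ccc(F)cc1)NC(=O)c1cc(OC)c(OC)c(OC)c1` is compound 1 with one change, (fluoro in place of hydrogen on an aromatic carbon), and in this assay compound 2 gives 28600 nM, which is a 1.1-fold lower number from compound 1 to compound 2 (0.06 log units; within the scatter). Compound 4 `COC(=O)[C@H](CSCc1ccc(F)cc1)NC(=O)c1cc(O)c(O)c(O)c1` is compound 3 with the same change, (fluoro in place of hydrogen on an aromatic carbon), and it has not yet been measured in this assay. The step from compound 3 to compound 4 is expected to be a 1.1-fold lower number from compound 3 to compound 4 (0.04 log units; within the scatter), an expectation that rests on the matching change on the other core having given a 1.1-fold lower number from compound 1 to compound 2 (0.06 log units; within the scatter). Compound 4 is therefore estimated at 55000 nM in this assay, most likely falling between 30000 nM and 100000 nM.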

Compound 4, half-maximal inhibitory concentration: 50200 nM
The estimate for compound 4 lay 1.1-fold (0.04 log units) above the measured number; the measured number falls inside the stated range.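

In this assay, replacing benzyl with 4-fluorobenzyl on the core of compound 3 gives a 1.2-fold lower number from compound 3 to compound 4 (0.08 log units; within the scatter), a step too small to count as a real change. Set beside the earlier step, the same change behaves alike on the two cores: the same change on two cores in this assay, a 1.1-fold lower number (0.06 log units; within the scatter) from compound 1 to compound 2 and a 1.2-fold lower number (0.08 log units; within the scatter) from compound 3 to compound 4, 1.1-fold (0.02 log units) apart, within the scatter of two such steps This shows that, in these two pairs, the change carries from one core to the other and leaves the number within the usual scatter, but it does not show that fluoro does anything to inhibition, and two steps this small agreeing says little about how the change would behave on any other core.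

The compounds shown leave open whether another group in the place of the fluoro, such as chloro, methoxy or trifluoromethyl, would move the number beyond the scatter. They also leave open what a carboxylic acid or an amide in place of the methyl ester would do on either core.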